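The source may report more compounds than this note shows. Statements on the series, on what has been measured and on what is new or still open speak of the compounds shown alone.

All numbers below come from a functional assay on KB-VIN10 cells (Homo sapiens) for inhibition, with a stated time of 72 h; a higher number here means a weaker inhibitor, a lower number a stronger inhibitor.

Measured compounds:
compound 1 `COc1ccc(S(=O)(=O)N2CCc3cccc(-c4ccc([N+](=O)[O-])cc4)c32)cc1` — 51.3 nM
compound 2 `COc1ccc(S(=O)(=O)N2CCc3cccc(-c4ccc(N(C)C)cc4)c32)cc1` — 553 nM
compound 3 `COc1ccc(-c2cccc3c2N(S(=O)(=O)c2ccc(OC)cc2)CC3)cc1` — 352 nM

Compound 1 has the lowest of the three numbers in this assay. Both changes made to it so far raise the number: an 11-fold higher number from compound 1 to compound 2 (1.03 log units; beyond the scatter) and a 6.9-fold higher number from compound 1 to compound 3 (0.84 log units; beyond the scatter). Between the two altered compounds the gap is small, a 1.6-fold lower number from compound 2 to compound 3 (0.20 log units; within the scatter), so neither of them can be ordered against the other.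

The next compound, compound 4 `COc1ccc(S(=O)(=O)N2CCc3cccc(-c4cccc(F)c4)c32)cc1`, is again a change at the same place on the core of compound 1: 3-fluorophenyl in place of 4-nitrophenyl on an aromatic carbon. For the measured compounds named here, no measured step replaces 4-nitrophenyl with 3-fluorophenyl, so there is no direct precedent. What bears on it is that both recorded departures from 4-nitrophenyl at this position, an 11-fold higher number from compound 1 to compound 2 (1.03 log units; beyond the scatter) and a 6.9-fold higher number from compound 1 to compound 3 (0.84 log units; beyond the scatter), moved the number upward, the one large and the other modest. Going by the values given here, on that basis a higher number than compound 1 is expected for compound 4 in this assay, of roughly the size seen for compound 3, with wide uncertainty since the entering group has no counterpart among the measured compounds.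

Compound 4 is therefore estimated at 250 nM, with a range of 80 nM to 800 nM. This estimate corresponds to an expected 4.9-fold higher number from compound 1 to compound 4 (0.69 log units; beyond the scatter).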

Compound 4, half-maximal inhibitory concentration: 92.4 nM
Compound 4: the middle estimate sits 2.7-fold (0.43 log units) above what was measured, within the range that was stated.
By their numbers in this assay, from the lowest: compounds 1 and 4 (each within the scatter of the next); then compounds 3 and 2 (each within the scatter of the next).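

In this assay, a 1.8-fold higher number from compound 1 to compound 4 (0.26 log units; within the scatter), which makes 3-fluorophenyl the only replacement of 4-nitrophenyl shown here that cannot be separated from it at this position on the shared core. The upward moves seen with compound 2 and compound 3 therefore do not hold for every replacement of 4-nitrophenyl, and compound 4 is the exception to them. The aryl group at this position still matters, as the two other steps lie beyond the scatter: a 3.8-fold lower number from compound 3 to compound 4 (0.58 log units; beyond the scatter) and a 6.0-fold lower number from compound 2 to compound 4 (0.78 log units; beyond the scatter). No data on hand explain these differences.

The compounds shown leave open whether the separation of compound 4 from compound 2 and compound 3 follows from the identity of the substituent or from where it sits on the phenyl ring, since 3-fluorophenyl differs from 4-methoxyphenyl and 4-(dimethylamino)phenyl in both respects. Also open, as far as these compounds go, is how unsubstituted phenyl, 4-fluorophenyl, 3-nitrophenyl, or a phenyl carrying a carboxylic acid or a primary amine would compare at this position.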